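Ether substituent variation: from compound 2 to compound 3

This account rests on a few compounds, and the source may have more. Where it says the series, first, only, none or still open, it means among the compounds named here.

Compound 1 `CCCN(CCC)c1nc(C(C)(C)C)ccc1CNC(=O)C(C)c1ccc(NS(C)(=O)=O)c(F)c1` and compound 2 `CC(C)Oc1nc(C(C)(C)C)ccc1CNC(=O)C(C)c1ccc(NS(C)(=O)=O)c(F)c1` share one core and differ at a single aromatic carbon. In an assay on cells for antagonist activity at transient receptor potential cation channel subfamily V member 1 (Homo sapiens), read by FLIPR and calcium flux, with a stated time of 6 min (a higher number here means a weaker inhibitor, a lower number a stronger inhibitor), compound 1 gives 2.5 nM, and compound 2 gives 2.3 nM. The step of a 1.1-fold lower number from compound 1 to compound 2 (0.04 log units; within the scatter) shows that dipropylamino and isopropoxy at this carbon give numbers that cannot be told apart; compound 2 therefore sits alongside compound 1 at the bottom of the two numbers, the gap between them being within the scatter.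

Compound 3 `COCCCOc1nc(C(C)(C)C)ccc1CNC(=O)C(C)c1ccc(NS(C)(=O)=O)c(F)c1` is not yet measured. It differs from compound 2 by 3-methoxypropyl in place of isopropyl on an oxygen on an aromatic ring. Among the compounds with values here, no measured step covers this exchange; the only known step, a 1.1-fold lower number from compound 1 to compound 2 (0.04 log units; within the scatter), concerns a different group at the same place and was small. On that basis the step is expected to be about a 1.3-fold higher number from compound 2 to compound 3 (0.12 log units; within the scatter), with no direction claimed beyond the scatter. Compound 3 is thus estimated at 3 nM, ranging from 1.2 nM to 8 nM.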

Compound 3, inhibition constant: 5.6 nM
Compound 3: middle estimate off by 1.9-fold (0.27 log units), on the low side, within the range that was stated.
By their numbers in this assay, from the lowest: compounds 2 and 1 (each within the scatter of the next); then compound 3.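

In this assay this position no longer looks indifferent to the group it carries: a 2.4-fold higher number from compound 2 to compound 3 (0.39 log units; beyond the scatter) is a step beyond the scatter, whereas dipropylamino and isopropoxy could not be told apart. The comparison with dipropylamino points the same way, with a 2.2-fold higher number from compound 1 to compound 3 (0.35 log units; beyond the scatter) also beyond the scatter, so 3-methoxypropoxy separates from both earlier groups. Both steps are modest, so the oxygen on the aromatic ring accepts 3-methoxypropyl with only a limited change in the number.

Still open, from the compounds shown here alone, is whether the shift follows the ether oxygen in the chain or the chain itself, which an unbranched butoxy group would test, and how a terminal amine or a carboxylic acid on the same chain would read. No measurement at hand gives a reason for either step.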